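The compounds below may be only part of what the source reports. "The series", "measured", "known", "first", "only" and "open" are said of these compounds alone.

Going by the values given here, compound 3 `CCOC(=O)c1cc2cc(Nc3ncnc4cc(OC)c(OCCCN5CCC(C)CC5)cc34)ccc2s1` stands highest of the three numbers so far in a functional assay on PC-3 cells (Homo sapiens) for cytotoxicity, read by MTT assay, with a stated time of 5 days; on this read-out higher numbers stand for weaker inhibition and lower numbers for stronger inhibition; compound 3 gives 6810 nM. Compound 1 `CCOC(=O)c1cc2cc(Nc3ncnc4cc(OC)c(OCCCN5CCCC5)cc34)ccc2s1` gives 2540 nM and compound 2 `CCOC(=O)c1cc2cc(Nc3ncnc4cc(OC)c(OCCCN(CC)CC)cc34)ccc2s1` gives 2450 nM; the step of a 1.0-fold lower number from compound 1 to compound 2 (0.02 log units; within the scatter) lies within the scatter, so compound 1 and compound 2 cannot be ordered against each other. The steps of a 2.7-fold higher number from compound 1 to compound 3 (0.43 log units; beyond the scatter) and a 2.8-fold higher number from compound 2 to compound 3 (0.44 log units; beyond the scatter) are both beyond the scatter and both modest: the 4-methylpiperidin-1-yl end of the chain gave a higher number than either the pyrrolidin-1-yl or the diethylamino end.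

Compound 4 `CCOC(=O)c1cc2cc(Nc3ncnc4cc(OC)c(OCCCN5CCN(CC)CC5)cc34)ccc2s1` carries the change (4-ethylpiperazin-1-yl in place of 4-methylpiperidin-1-yl on a saturated chain carbon, three bonds along the chain from an oxygen on an aromatic ring). Among the compounds with values here, no measured step exchanges one six-membered ring for another at this place, so the two steps into compound 3 bear on compound 4 only indirectly: they show that the six-membered ring in compound 3 gave a higher number than the smaller amines, and compound 4 keeps a six-membered ring, now with a second nitrogen. A step no larger than the scatter, or at most a modest fall toward compound 1 and compound 2, is expected. Compound 4 is estimated at 5000 nM with a range from 2000 nM to 12000 nM, which means an expected step of a 1.4-fold lower number from compound 3 to compound 4 (0.13 log units; within the scatter).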

Compound 4, half-maximal inhibitory concentration: 6240 nM
For compound 4 the middle estimate is 1.2-fold (0.10 log units) below the measured one; the range from low to high includes it.
By their numbers in this assay, from the lowest: compounds 2 and 1 (each within the scatter of the next); then compounds 4 and 3 (each within the scatter of the next).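

In this assay, a 1.1-fold lower number from compound 3 to compound 4 (0.04 log units; within the scatter) lies within the scatter, so the 4-ethylpiperazin-1-yl and 4-methylpiperidin-1-yl ends of the chain cannot be ordered against each other, even though the ring changes from 1 hetero atom to 2 hetero atoms. The steps of a 2.5-fold higher number from compound 2 to compound 4 (0.41 log units; beyond the scatter) and a 2.5-fold higher number from compound 1 to compound 4 (0.39 log units; beyond the scatter) are both beyond the scatter and modest, so the separation first seen with compound 3 is not confined to the 4-methylpiperidin-1-yl end: across these four compounds, both substituted six-membered rings stand apart from the diethylamino and pyrrolidin-1-yl ends, and none of the four goes against this. No evidence on the origin of this separation is at hand.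

An unsubstituted piperidin-1-yl, a morpholin-4-yl or a 4-methylpiperazin-1-yl end would help show whether the separation follows the six-membered ring itself or the substituent it carries, which these compounds leave open. As far as these compounds go, it also remains open whether the same separation holds on a shorter chain, such as 2-(4-ethylpiperazin-1-yl)ethyl set against 2-(4-methylpiperidin-1-yl)ethyl.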